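Methyl for methoxy on two chromone-derived scaffolds

The source may hold more compounds than are shown below. What is called first, only, known or untested is meant among the compounds shown, and "the series" means these compounds.

Measured compounds:
- compound 1, `COc1ccc(-c2cc(=O)c3ccc(F)cc3o2)cc1`: 1340 nM
- compound 2, `Cc1ccc(-c2cc(=O)c3ccc(F)cc3o2)cc1`: 4330 nM
- compound 3, `COc1ccc(C2CC(=O)c3ccc(OC)cc3O2)cc1`: 7180 nM

In an in vitro assay on BTI-TN-5B1-4 cells for inhibition of Amine oxidase [flavin-containing] B (Homo sapiens) (a lower number here means a stronger inhibitor, a higher number a weaker inhibitor), compound 1 gives 1340 nM, and compound 2 gives 4330 nM. The change from compound 1 to compound 2 is methyl in place of methoxy on an aromatic carbon and it made a 3.2-fold higher number from compound 1 to compound 2 (0.51 log units; beyond the scatter). Compound 3 gives 7180 nM; how its core differs from the core of compound 1 is not broken down here. Compound 4, `COc1ccc2c(c1)OC(c1ccc(C)cc1)CC2=O`, is not yet measured; it differs from compound 3 by methyl in place of methoxy on an aromatic carbon, the same change seen between compound 1 and compound 2, at the same kind of place. Since that earlier change made a 3.2-fold higher number from compound 1 to compound 2 (0.51 log units; beyond the scatter), a step of similar size is expected for compound 4, namely a 2.8-fold higher number from compound 3 to compound 4 (0.44 log units; beyond the scatter). Compound 4 is therefore estimated at 20000 nM, likely between 8000 nM and 50000 nM.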

Compound 4, half-maximal inhibitory concentration: 550 nM
Compound 4: the middle estimate sits 36-fold (1.56 log units) above what was measured, and the stated range ends above it.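

In this assay, methyl in place of methoxy on an aromatic carbon gave a 13-fold lower number from compound 3 to compound 4 (1.12 log units; beyond the scatter), so the change did not carry over from the earlier pair in size or in direction: the same change on two cores in this assay, a 3.2-fold higher number (0.51 log units; beyond the scatter) from compound 1 to compound 2 and a 13-fold lower number (1.12 log units; beyond the scatter) from compound 3 to compound 4, 42-fold (1.63 log units) apart, beyond the scatter of two such steps. Among these compounds, the step read on one core was therefore no guide to the same change on the other. These two pairs do not show which difference between the core of compound 1 and the core of compound 3 goes with the reversal. The compounds shown leave open how an amine, a carboxylic acid or a longer chain such as ethoxy would fare at this place on either core. They also leave open whether the reversal would recur on any further core.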